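A few compounds are considered here, and "the series" means these few. Any claim that something is new, unique, unknown or untested is made for them only; others in the source may bear on it.

- compound 1 `COc1cc(C(=O)c2ccc3c(ccn3C)c2)cc(OC)c1OC` gives 11.2 nM
- compound 2 `CCn1ccc2cc(C(=O)c3cc(OC)c(OC)c(OC)c3)ccc21` gives 31 nM

Going by the values given here, in a functional assay on MKN-45 cells (Homo sapiens) for inhibition, with a stated time of 72 h (on this read-out higher numbers stand for weaker inhibition and lower numbers for stronger inhibition), compound 2 holds the higher of the two numbers, and compound 1 is its only measured neighbour. Compound 3 `CCCn1ccc2cc(C(=O)c3cc(OC)c(OC)c(OC)c3)ccc21` differs from compound 2 by methyl in place of hydrogen on a saturated chain carbon, two bonds along the chain from an aromatic nitrogen and so carries methyl in place of hydrogen on a saturated chain carbon, two bonds along the chain from an aromatic nitrogen. Among the compounds with values here, one measured step bears on this change: methyl in place of hydrogen on a saturated chain carbon bound to an aromatic nitrogen gave a 2.8-fold higher number from compound 1 to compound 2 (0.44 log units; beyond the scatter) and was a modest loss. This single step cannot show whether the trend continues along the chain, but a further rise of similar size is expected. The expected change is a 2.3-fold higher number from compound 2 to compound 3 (0.35 log units; beyond the scatter) and remains uncertain. Compound 3 is estimated at 70 nM with an expected range from 28 nM to 175 nM.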

Compound 3, half-maximal inhibitory concentration: 680 nM
Compound 3: middle estimate off by 9.7-fold (0.99 log units), on the low side; measured number outside the range, above it.
By their numbers in this assay, from the lowest: compound 1; then compound 2; then compound 3.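

In this assay the change from ethyl to propyl on the chain bound to an aromatic nitrogen gives a 22-fold higher number from compound 2 to compound 3 (1.34 log units; beyond the scatter) and so weighs far more than the earlier change, which gave a 2.8-fold higher number from compound 1 to compound 2 (0.44 log units; beyond the scatter) at the carbon bound to that nitrogen. Across both changes the chain as a whole gives a 61-fold higher number from compound 1 to compound 3 (1.78 log units; beyond the scatter) and the rise is uneven, with the carbon two bonds along the chain accounting for most of it. Nothing measured here explains why this one extra methyl has so large an effect.

The compounds shown leave open whether a longer chain such as butyl would raise the number further or whether the rise levels off. They also leave open how a branched chain such as isopropyl, or a chain ending in an amine or a hydroxyl group, would behave at this place.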